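Anilino-substituted series on MV4-11 cells, one analogue estimated

The source may report more compounds than this note shows. Statements on the series, on what has been measured and on what is new or still open speak of the compounds shown alone.

Measured compounds:
compound 1 `Cc1n[nH]c2ccc(-c3nc4cnc(N5CCN(C)CC5)cn4c3Nc3cccc(F)c3)cc12` — "not determined" (no result reported) in a functional assay on MV4-11 cells (Homo sapiens) for inhibition, with a stated time of 120 h; a lower number here means a stronger inhibitor, a higher number a weaker inhibitor
compound 2 `Cc1n[nH]c2ccc(-c3nc4cnc(N5CCN(C)CC5)cn4c3Nc3ccc(F)cc3)cc12` — 32300 nM
compound 3 `Cc1n[nH]c2ccc(-c3nc4cnc(N5CCN(C)CC5)cn4c3Nc3ccccc3)cc12` — "not determined" (no result reported)

Compound 1 stands without a number of its own: in this assay compound 1 is entered as "not determined" (no result reported). Compound 3 is in the same position, entered as "not determined" (no result reported). The only figure in the set belongs to compound 2, which in this assay gives 32300 nM, a weak value. For the measured compounds named here, no step between two measured compounds can be drawn from these three, so nothing is known about how a change at the anilino group moves the read-out.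

Compound 4 `Cc1n[nH]c2ccc(-c3nc4cnc(N5CCN(C)CC5)cn4c3Nc3ccc(Cl)cc3F)cc12` differs from compound 1 as follows: 4-chloro-2-fluorophenyl in place of 3-fluorophenyl on a nitrogen on an aromatic ring. Going by the values given here, without a measured step for comparison, the size and direction of the change from compound 1 to compound 4 cannot be stated from the data; only the single value of compound 2 gives a scale for the series.

Taking the value of compound 2, 32300 nM, as the sole anchor, compound 4 is estimated at 20000 nM, expected to fall between 4000 nM and 100000 nM.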

Compound 4, half-maximal inhibitory concentration: 10400 nM
For compound 4 the middle estimate is 1.9-fold (0.28 log units) above the measured one; measured number inside the range.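

In this assay the series now has its first measured step at this position: 4-chloro-2-fluorophenyl in place of 4-fluorophenyl on the nitrogen gives a 3.1-fold lower number from compound 2 to compound 4 (0.49 log units; beyond the scatter), a modest change but one beyond the usual scatter. The read-out therefore responds to a change in the substituents of this phenyl ring, although compound 4, at 10400 nM, remains a weak inhibitor. No supporting data bear on the reason for this shift, and this single exchange cannot separate the contribution of the chloro group from that of the added fluoro group. Steps involving compound 1 and compound 3 cannot be read, so the standing of the 3-fluorophenyl and unsubstituted phenyl groups stays unknown. Also open, as far as these compounds go, is how a methoxy group, a nitrile or a dimethylamino group on this phenyl ring would move the read-out.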